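The source may report more compounds than this note shows. Statements on the series, on what has been measured and on what is new or still open speak of the compounds shown alone.

Measured so far in an ADME assay on HEK293 cells (Homo sapiens) for cytotoxicity, read by CellTiter-Glo and resazurin assay, with a stated time of 72 h; a lower number here means that less compound is needed, a higher number that more compound is needed for the effect:
Compound 1 `CCOC(=O)CCCCCOc1cccc(CN(C(=O)c2ccc(-c3cccc(-c4ccccc4)c3)cc2)C(C)C)c1` gives only a limit of the assay, > 26000 nM.
Compound 2 `CCOC(=O)CCCCCOc1cccc(CN(C(=O)c2ccc(-c3cccc(Oc4ccccc4)c3)cc2)C(C)C)c1` gives only a limit of the assay, > 19600 nM.
Compound 3 `CCOC(=O)CCCCCOc1cccc(CN(C(=O)c2ccc(-c3ccc4cc[nH]c4c3)cc2)C(C)C)c1` gives only a limit of the assay, > 26000 nM.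

Compound 3 therefore stands at a limit in this assay, and the two other values are limits too, as the limit of > 26000 nM in this assay, at which 2 of the 3 values shown sit, and the limit of > 19600 nM in this assay, at which 1 of the 3 values shown sits, show. The two measured steps, a step that the two limits leave unreadable from compound 1 to compound 2 and a step that the two limits leave unreadable from compound 1 to compound 3, have no readable size or direction. Compound 4 `CCOC(=O)CCCCCOc1cccc(CN(C(=O)c2ccc(-c3cccc(CC(=O)O)c3)cc2)C(C)C)c1` arises from compound 3 by 3-(carboxymethyl)phenyl in place of 1H-indol-6-yl on an aromatic carbon. Since neither measured step can be read, no step beyond the scatter is expected in this assay in either direction, and compound 4 is expected to give a value near 30000 nM, in a range from 10000 nM to 100000 nM, most likely again as a limit. The expected step that the limit leaves unreadable from compound 3 to compound 4 is thus estimated as essentially none.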

Compound 4, half-maximal effective concentration: > 26000 nM
Compound 4 was reported as a limit; the forecaster's own chance of this, stated with the estimate: 80%; the middle value does not contradict the limit.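

In this assay compound 4 gives > 26000 nM, which is a limit. Its steps from compound 1, compound 2 and compound 3 therefore cannot be read. The compounds shown leave open what actual half-maximal concentration any of them has, and whether any of these changes shifts it.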